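From benzyl to 4-methylbenzyl: the step to compound 3

The compounds below may be only part of what the source reports. "The series", "measured", "known", "first", "only" and "open" are said of these compounds alone.

In a functional assay on DU-145 cells (Homo sapiens) for cytotoxicity, read by MTT assay (on this read-out lower numbers stand for stronger inhibition and higher numbers for weaker inhibition), compound 1 `COc1ccc2cc([C@H](C)c3nnc(SCc4ccc(F)cc4)n3-c3ccc(Cl)cc3)ccc2c1` gives 33600 nM and compound 2 `COc1ccc2cc([C@H](C)c3nnc(SCc4ccccc4)n3-c3ccc(Cl)cc3)ccc2c1` gives 35800 nM. Going by the values given here, these are the only two numbers available, so compound 2 stands level with compound 1, and no ordering can be drawn between them. Compound 3 `COc1ccc2cc([C@H](C)c3nnc(SCc4ccc(C)cc4)n3-c3ccc(Cl)cc3)ccc2c1` is compound 2 with methyl in place of hydrogen on an aromatic carbon, para to a large group: methyl in place of hydrogen on an aromatic carbon. The benzylsulfanyl group thus becomes (4-methylbenzyl)sulfanyl. Among the compounds with values here, one measured step bears on this change, as it concerns the same aromatic carbon, with hydrogen in place of fluoro: a 1.1-fold higher number from compound 1 to compound 2 (0.03 log units; within the scatter). Within the data shown here, no measured compound carries a methyl there, so this single comparison is thin support. Among the measured compounds shown here, with only that step to go on, no shift beyond the scatter is expected in this assay, in either direction. The expected step is a 1.1-fold lower number from compound 2 to compound 3 (0.02 log units; within the scatter). Compound 3 is estimated at 34000 nM, with an expected range from 17000 nM to 65000 nM.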

Compound 3, half-maximal inhibitory concentration: 18800 nM
The estimate for compound 3 lay 1.8-fold (0.26 log units) above the measured number, and the stated range covers the measured number.
By their numbers in this assay, from the lowest: compounds 3, 1 and 2 (each within the scatter of the next).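

In this assay the new methyl group gives a 1.9-fold lower number from compound 2 to compound 3 (0.28 log units; within the scatter) and, set against fluoro on the same aromatic carbon, it gives a 1.8-fold lower number from compound 1 to compound 3 (0.25 log units; within the scatter) so neither step leaves the scatter. The earlier pair had shown this only for fluoro and hydrogen, whereas the series now shows that a group carrying a carbon atom can also stand on this carbon without a shift beyond the scatter, and hydrogen, fluoro and methyl cannot be ranked here. Nothing available explains the numbers at this position.

As far as these compounds go, all three compounds remain close together, so it stays open whether a group of another kind on this carbon, such as an amine, a carboxylic acid or a longer chain like butyl, would move the number beyond the scatter. From the compounds shown here alone, it is equally open whether moving the methyl to another carbon of the ring, or changing the shared core of compound 1 elsewhere, would have a larger effect than the changes seen so far.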